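Methyl for methylamino: expected step in the series

The source may hold more compounds than are shown below. What is called first, only, known or untested is meant among the compounds shown, and "the series" means these compounds.

In a functional assay (aorta) for inhibition, with Rattus norvegicus as the target, with a stated time of 8 days (a lower number here means a stronger inhibitor, a higher number a weaker inhibitor), compound 2 (`CNc1nsc(-c2ccc(N3CCN(c4cccc(C(F)(F)F)c4)CC3)nn2)n1`) gives 3 nM and stands highest of the two single numbers. Compound 1 (`Cc1nsc(-c2ccc(N3CCN(c4cccc(Cl)c4)CC3)nn2)n1`) gives the other (0.6 nM), lower by more than the scatter. Compound 3 (`CN(C)c1nsc(-c2ccc(N3CCN(c4cccc(C(F)(F)F)c4)CC3)nn2)n1`) has no single number, its entries lying far apart (6 nM; 0.4 nM (2 entries)). Compound 4 (`Cc1nsc(-c2ccc(N3CCN(c4cccc(C(F)(F)F)c4)CC3)nn2)n1`) is compound 2 with methyl in place of methylamino on an aromatic carbon. Among the measured compounds shown here, no measured step isolates this change. Compound 1 carries the same methyl at (0.6 nM), though it differs elsewhere from compound 4. The expected step of a 2.0-fold lower number from compound 2 to compound 4 (0.30 log units; within the scatter) is a small fall, about the size of the scatter. For compound 4 the estimated value is (1.5 nM), with an expected range from 0.3 nM to 8 nM.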

Compound 4, half-maximal inhibitory concentration: 0.3 nM
Compound 4: the middle estimate sits 5.0-fold (0.70 log units) above what was measured; low and high end bracket the measured number.
By their numbers in this assay, from the lowest: compounds 4 and 1 (each within the scatter of the next); then compound 2.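

Methyl in place of methylamino, on the aromatic carbon between two ring nitrogen atoms, now has a single-place comparison: in this assay there is a 10-fold lower number from compound 2 to compound 4 (1.00 log units; beyond the scatter). This position therefore responds to the change, and by more than the scatter. Trifluoromethyl in place of chloro gives a 2.0-fold lower number from compound 1 to compound 4 (0.30 log units; within the scatter), so that swap cannot be told from the scatter.

Going by these compounds, how ethyl, methoxy or a bare hydrogen at this position would compare with methyl remains open. On these data alone, how firmly single entries can be read also remains open: the several entries of compound 3 in this assay, 6 nM; 0.4 nM (2 entries).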